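Cutting back the oxan-4-yl chain of compound 3

A few compounds are considered here, and "the series" means these few. Any claim that something is new, unique, unknown or untested is made for them only; others in the source may bear on it.

Values in a physicochemical assay for lipophilicity, using the shake flask method, measured as octanol-water partition, at pH 7.4 (a lower number here means a more polar compound, a higher number a more lipophilic compound), so far
Compound 1 `COc1cc(F)ccc1-c1ccnc2[nH]c(C3CCN(CC(=O)N(C)C)CC3)cc12` gives 2.9
Compound 2 `CC(C)n1cc(-c2ccnc3[nH]c(C4CCN(CC(=O)N(C)C)CC4)cc23)ccc1=O` gives 1.9
Compound 3 `CN(C)C(=O)CN1CCC(c2cc3c(-c4ccc(=O)n(CCC5CCOCC5)c4)ccnc3[nH]2)CC1` gives 1.5

Compound 3 is the lowest of these three, and the values of compound 2 and compound 1 both lie higher beyond the scatter. The next compound is compound 4 `CCn1cc(-c2ccnc3[nH]c(C4CCN(CC(=O)N(C)C)CC4)cc23)ccc1=O` and its difference from compound 3 is hydrogen in place of oxan-4-yl on a saturated chain carbon, two bonds along the chain from an aromatic nitrogen with hydrogen in place of oxan-4-yl on a saturated chain carbon, two bonds along the chain from an aromatic nitrogen. Cut one bond further out, this reads 2-(oxan-4-yl)ethyl to ethyl.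

The measured step that bears most directly is a number 0.40 log units lower from compound 2 to compound 3 (beyond the scatter) and it was modest, with 2-(oxan-4-yl)ethyl in place of isopropyl on an aromatic nitrogen. The change to compound 4 runs the opposite way but ends at ethyl and not at isopropyl, so only part of that size is expected to return. The other measured step, a number 1.00 log units lower from compound 1 to compound 2 (beyond the scatter) in size, exchanges a whole aromatic group and offers little guidance for a change on this chain. The estimated step is a number 0.10 log units higher from compound 3 to compound 4 (within the scatter) and no change beyond the scatter is expected. Compound 4 is estimated at 1.6 within an expected range of 1.3 to 1.9 on this read-out.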

Compound 4, distribution coefficient: 1.2
For compound 4 the middle estimate is 0.40 log units above the measured one; the measured number lies below the stated range.
By their numbers in this assay, from the lowest: compounds 4 and 3 (each within the scatter of the next); then compound 2; then compound 1.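

In this assay the whole oxan-4-yl can be taken off the chain on the aromatic nitrogen with only a number 0.30 log units lower from compound 3 to compound 4 (within the scatter), so at this position 2-(oxan-4-yl)ethyl and ethyl are not told apart. A far smaller edit on the same nitrogen counts for more: isopropyl to ethyl, which is hydrogen in place of methyl, gives a number 0.70 log units lower from compound 2 to compound 4 (beyond the scatter), so heavy-atom count alone does not track the read-out across these three groups. With ethyl in place, the exchange of the aromatic group on the shared core gives a number 1.70 log units lower from compound 1 to compound 4 (beyond the scatter), the largest step among these compounds, although the groups exchanged have equal heavy-atom counts. No measurement in hand gives a cause for any of these steps.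

A straight propyl chain on the aromatic nitrogen would show whether the step from compound 2 follows the branching of isopropyl or the carbon count alone. From the compounds shown here alone, a chain ending in an amine or a carboxylic acid remains open, as does whether such a terminal group would move the read-out where oxan-4-yl stayed within the scatter.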